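A Chlorine Added to the Phenyl of Compound 2

The compounds below may be only part of what the source reports. "The series", "measured", "known", "first", "only" and "open" are said of these compounds alone.

Three compounds share one core and differ only at the fused ring. In a functional assay on A549 cells (Homo sapiens) for cytotoxicity, read by MTT assay, with a stated time of 72 h (on this read-out higher numbers stand for weaker inhibition and lower numbers for stronger inhibition), compound 1 `O=C(Nc1nc2ccccc2s1)c1cn(-c2ccccc2)nc1-c1ccccc1` gives 13500 nM, compound 2 `O=C(Nc1nc2ccc(F)cc2s1)c1cn(-c2ccccc2)nc1-c1ccccc1` gives 10200 nM, and compound 3 `Cc1ccc2nc(NC(=O)c3cn(-c4ccccc4)nc3-c3ccccc3)sc2c1` gives 26500 nM. Compound 2 carries the lowest of the three numbers, yet the step of a 1.3-fold lower number from compound 1 to compound 2 (0.12 log units; within the scatter) lies within the scatter, so compound 1 and compound 2 cannot be told apart; only a 2.6-fold higher number from compound 2 to compound 3 (0.41 log units; beyond the scatter) is beyond it. Compound 4 `O=C(Nc1nc2ccc(F)cc2s1)c1cn(-c2ccccc2)nc1-c1ccc(Cl)cc1` differs from compound 2 by chloro in place of hydrogen on an aromatic carbon. Going by the values given here, no measured step touches this ring: a 1.3-fold lower number from compound 1 to compound 2 (0.12 log units; within the scatter) and a 2.0-fold higher number from compound 1 to compound 3 (0.29 log units; within the scatter) sit on the fused ring and were small. With no guide at this position, the expected change from compound 2 to compound 4 is a 1.1-fold lower number from compound 2 to compound 4 (0.05 log units; within the scatter), nothing beyond the scatter. Compound 4 is therefore estimated at 9000 nM, within a range from 4500 nM to 18000 nM.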

Compound 4, half-maximal inhibitory concentration: 8860 nM
For compound 4 the middle estimate is 1.0-fold (0.01 log units) above the measured one, and the stated range covers the measured number.
By their numbers in this assay, from the lowest: compounds 4, 2, 1 and 3 (each within the scatter of the next, the first and the last beyond it).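

Moving to the phenyl, the change from phenyl to 4-chlorophenyl gives a 1.2-fold lower number from compound 2 to compound 4 (0.06 log units; within the scatter) in this assay, so compound 2 and compound 4 cannot be told apart. Going by these compounds alone, this is the first measured step away from the fused ring, and it shows that a single chlorine at this place leaves the read-out within the scatter. Nothing shown gives a reason for the size of this step. Still open, as far as these compounds go, is whether an amine, a carboxylic acid or a longer chain at this place would do the same. From the compounds shown here alone, the second phenyl of the shared core also remains open.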